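The source may hold more compounds than are shown below. What is called first, only, known or untested is meant among the compounds shown, and "the series" means these compounds.

Measured compounds:
- compound 1, `COc1cccc(NC(=O)Oc2cc(=O)n(CCCO)c3c2CC(C/C=C(\C)CCC=C(C)C)C(C)(C)C3)c1`, in a functional assay on PANC-1 cells (Homo sapiens) for inhibition, read by MTT assay, with a stated time of 24 h, tested at 10 uM (a lower number here means less inhibition, a higher number more inhibition at the concentration tested (going by the name of the read-out)), compound 1 gives 47%
- compound 2, `COc1ccccc1NC(=O)Oc1cc(=O)n(CCCO)c2c1CC(C/C=C(\C)CCC=C(C)C)C(C)(C)C2`, in this assay compound 2 gives 53%

Both compounds share the same core and differ only in the group on the amide-type nitrogen. Compound 2 shows the larger of the two numbers, but the step of a number 6 percentage points higher from compound 1 to compound 2 (within the scatter) lies within the scatter, so on the numbers shown the two compounds cannot be told apart.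

Compound 3, `CC(C)=CCC/C(C)=C/CC1Cc2c(OC(=O)Nc3cccc(F)c3)cc(=O)n(CCCO)c2CC1(C)C`, is not yet measured. It differs from compound 2 in one place: 3-fluorophenyl in place of 2-methoxyphenyl on an amide-type nitrogen. For the measured compounds named here, the single measured step, from compound 1 to compound 2, exchanged 2-methoxyphenyl for 3-methoxyphenyl on that same nitrogen and changed the read-out only within the scatter. It involves neither the loss of a methoxy group nor the arrival of fluorine, so it bears on the present change only loosely. Going by the values given here, with one small step as the only guide, no movement beyond the scatter is expected in this assay, and the estimated step of a number 3 percentage points lower from compound 2 to compound 3 (within the scatter) is accordingly small. Compound 3 is therefore expected to give about 50%, in a range from 30% to 70%.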

Compound 3, a percentage reported as inhibition, at one concentration (the size of the read-out at that concentration, not a potency): 52.3%
Estimate against measurement, compound 3: 2.3 percentage points below; measured number inside the range.
By their numbers in this assay, from the lowest: compounds 1, 3 and 2 (each within the scatter of the next).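

Swapping the ring on the amide-type nitrogen for 3-fluorophenyl gives, in this assay, a number 0.7 percentage points lower from compound 2 to compound 3 (within the scatter) and, with the fluoro in place of methoxy on an aromatic carbon, a number 5.3 percentage points higher from compound 1 to compound 3 (within the scatter) as well. Compounds 1 and 2 both carry a methoxy group, so they could not show what happens when that group leaves; these steps show that replacing it with fluorine does not take the read-out outside the scatter, whichever methoxyphenyl is the starting point. Among the three compounds, 2-methoxyphenyl, 3-methoxyphenyl and 3-fluorophenyl on this nitrogen therefore cannot be told apart in this measurement, and no measurement at hand explains that result.

The compounds shown leave open whether a plain phenyl ring, or a phenyl ring bearing an amine or a carboxylic acid, would give a number beyond the scatter on this nitrogen. They also leave open whether these three compounds would separate at other concentrations, since each number in this assay comes from a single concentration and is not a potency.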